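Fluorobenzyl series: amino-methyl pyrimidine analogue

The source may report more compounds than this note shows. Statements on the series, on what has been measured and on what is new or still open speak of the compounds shown alone.

compound 1 `CCc1c[nH]c(-c2nn(Cc3ccccc3F)c3ncccc23)n1`: 600 nM
compound 2 `Fc1ccccc1Cn1nc(-c2ncccn2)c2cccnc21`: 1250 nM

In a functional assay (aorta) with Oryctolagus cuniculus as the target (on this read-out higher numbers stand for weaker inhibition and lower numbers for stronger inhibition), compound 2 has the highest of the two numbers; its nearest neighbour is compound 1, separated by a 2.1-fold higher number from compound 1 to compound 2 (0.32 log units; beyond the scatter). Compound 3 `Cc1cc(N)nc(-c2nn(Cc3ccccc3F)c3ncccc23)n1` differs from compound 2 by 4-amino-6-methylpyrimidin-2-yl in place of pyrimidin-2-yl on an aromatic carbon. Going by the values given here, no measured step touches this kind of change: the only step available, a 2.1-fold higher number from compound 1 to compound 2 (0.32 log units; beyond the scatter), exchanges the whole ring rather than decorating it, and was modest. A step of similar or smaller size is therefore expected, in either direction. Compound 3 is expected to give 900 nM, with a range from 300 nM to 2700 nM. For compound 3 the expected step amounts to a 1.4-fold lower number from compound 2 to compound 3 (0.14 log units; within the scatter).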

Compound 3, half-maximal inhibitory concentration: 536000 nM
For compound 3 the middle estimate is 600-fold (2.77 log units) below the measured one; measured number outside the range, above it.
By their numbers in this assay, from the lowest: compound 1; then compound 2; then compound 3.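

In this assay the position proves far more sensitive to decoration of the pyrimidin-2-yl ring (a 430-fold higher number from compound 2 to compound 3 (2.63 log units; beyond the scatter)) than the ring exchange suggested (a 2.1-fold higher number from compound 1 to compound 2 (0.32 log units; beyond the scatter)). Replacing the 4-ethyl-1H-imidazol-2-yl group with 4-amino-6-methylpyrimidin-2-yl gives the widest gap in the series (an 890-fold higher number from compound 1 to compound 3 (2.95 log units; beyond the scatter)). No available evidence bears on the origin of this step.

Going by these compounds, the amine and the methyl enter together in compound 3, so their separate contributions remain open. On these data alone, whether a 4-methoxy or 4-chloro group on the pyrimidin-2-yl ring would give a similar step also remains open.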